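Cyano to Trifluoromethyl: Repeating a Change on a New Ring

The source may hold more compounds than are shown below. What is called first, only, known or untested is meant among the compounds shown, and "the series" means these compounds.

Of the compounds shown here, three built on one shared core have been measured. Compound 1 `CC/C(=C(/c1ccc(/C=C/C(=O)O)cc1)c1cc2ccccc2[nH]1)c1ccccc1C#N` carries a 2-cyanophenyl group on the double-bonded chain carbon; in a functional assay on MCF7 cells (Homo sapiens) for inhibition (on this read-out lower numbers stand for stronger inhibition and higher numbers for weaker inhibition), compound 1 gives 9 nM. Compound 2 `CC/C(=C(/c1ccc(/C=C/C(=O)O)cc1)c1cc2ccccc2[nH]1)c1ccccc1C(F)(F)F` differs from compound 1 by trifluoromethyl in place of cyano on an aromatic carbon; in this assay compound 2 gives 8 nM, so that a 1.1-fold lower number from compound 1 to compound 2 (0.05 log units; within the scatter). Compound 3 `CC/C(=C(/c1ccc(/C=C/C(=O)O)cc1)c1cc2ccccc2[nH]1)c1ccc(C#N)cc1Cl` differs from compound 1 by 2-chloro-4-cyanophenyl in place of 2-cyanophenyl on a double-bonded chain carbon bound to a double-bonded chain carbon and a saturated chain carbon; in this assay compound 3 gives 49 nM, which means a 5.4-fold higher number from compound 1 to compound 3 (0.74 log units; beyond the scatter) and a 6.1-fold higher number from compound 2 to compound 3 (0.79 log units; beyond the scatter).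

Compound 4 `CC/C(=C(/c1ccc(/C=C/C(=O)O)cc1)c1cc2ccccc2[nH]1)c1ccc(C(F)(F)F)cc1Cl` has not yet been measured. It differs from compound 3 by trifluoromethyl in place of cyano on an aromatic carbon. Among the compounds with values here, this is the same kind of change as the one from compound 1 to compound 2, though not the same: in compound 1 the cyano sits ortho to a large group, whereas in compound 3 it sits meta to a chloro group and para to a large group. Because a 1.1-fold lower number from compound 1 to compound 2 (0.05 log units; within the scatter) stayed within the usual scatter, the expectation is that compound 4 will stay close to compound 3, with an estimated step of a 1.1-fold lower number from compound 3 to compound 4 (0.04 log units; within the scatter). In this assay compound 4 is estimated at 45 nM, expected to fall between 20 nM and 110 nM. This rests on a single repeated change and on one reference pair, so the surroundings of the ring may yet shift the outcome.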

Compound 4, half-maximal inhibitory concentration: 27 nM
Compound 4: the middle estimate sits 1.7-fold (0.22 log units) above what was measured, within the range that was stated.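

In this assay, putting trifluoromethyl in place of cyano gave a similar result on both cores: the same change on two cores in this assay, a 1.1-fold lower number (0.05 log units; within the scatter) from compound 1 to compound 2 and a 1.8-fold lower number (0.26 log units; within the scatter) from compound 3 to compound 4, 1.6-fold (0.21 log units) apart, within the scatter of two such steps. The new step is a 1.8-fold lower number from compound 3 to compound 4 (0.26 log units; within the scatter), so this swap stays within the scatter in both pairs, while the larger steps come with replacing the whole aromatic group: there is a 3.4-fold higher number from compound 2 to compound 4 (0.53 log units; beyond the scatter), and there is a 3.0-fold higher number from compound 1 to compound 4 (0.48 log units; beyond the scatter). This suggests that the swap can be carried between these two cores with little effect on this read-out, but two pairs cannot show that it will hold on every core in the series, and they do not explain why the two steps agree.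

As far as these compounds go, what remains open is whether the same agreement would appear with a bromo or methoxy group in place of the chloro group, or on a core with an ethyl chain replaced by a longer chain. It is also open whether the swap would stay this quiet if the carboxylic acid gave way to an amide, since every compound shown here keeps the acid.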